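Saturated ring substituent change in the glucagon receptor series

The source may report more compounds than this note shows. Statements on the series, on what has been measured and on what is new or still open speak of the compounds shown alone.

Compound 1 `CC(C)c1ccc(NC(=O)N(Cc2ccc(C(=O)NCCC(=O)O)cc2)[C@H]2CC[C@H](C(C)(C)C)CC2)cc1` and compound 2 `CC(C)(C)[C@H]1CC[C@H](N(Cc2ccc(C(=O)NCCC(=O)O)cc2)C(=O)Nc2cc(Cl)cc(Cl)c2)CC1` share the core of the series. In an in vitro assay on BHK cells for inhibition of Glucagon receptor (Homo sapiens) (a higher number here means a weaker inhibitor, a lower number a stronger inhibitor), compound 1 gives 35 nM and compound 2 gives 80 nM. Between them the change is a 2.3-fold higher number from compound 1 to compound 2 (0.36 log units; beyond the scatter). Compound 3 `O=C(O)CCNC(=O)c1ccc(CN(C(=O)Nc2ccc(OC(F)(F)F)cc2)C2CCC(C(=O)NCC3CC3)CC2)cc1` is reported only as a limit of this assay, > 10000 nM. Compound 3 sits at the limit of > 10000 nM in this assay, at which 1 of the 3 values shown sits, so its place among the numbers is known only as a limit. Compound 4 `COC1CCC(N(Cc2ccc(C(=O)NCCC(=O)O)cc2)C(=O)Nc2ccc(OC(F)(F)F)cc2)CC1` differs from compound 3 by methoxy in place of (cyclopropylmethyl)carbamoyl on a saturated ring carbon. For the measured compounds named here, the only measured step alters the group on the amide-type nitrogen, not the saturated ring carbon, so no measured step bears directly on this change. The number for compound 4 is therefore expected near 5000 nM, within 1000 nM to 30000 nM. The step from compound 3 to compound 4 is estimated as an at least 2.0-fold lower number from compound 3 to compound 4 (0.30 log units; that floor lies within the scatter).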

Compound 4, half-maximal inhibitory concentration: > 10000 nM
Compound 4: only a limit was reported; the forecaster's own chance of this, stated with the estimate: 40%; middle value at least 2.0-fold (0.30 log units) from the limit.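

For the compounds shown here, compound 4 gives > 10000 nM, a limit of the assay; compound 3 is also reported only as a limit, so no step between them can be read. Open: how methoxy in place of (cyclopropylmethyl)carbamoyl alters the number.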